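The compounds below may be only part of what the source reports. "The series", "measured", "known", "first", "only" and "open" are said of these compounds alone.

Measured so far in a functional assay on OVCAR-3 cells (Homo sapiens) for antiproliferative activity, read by sulforhodamine B assay, with a stated time of 72 h; on this read-out higher numbers stand for weaker inhibition and lower numbers for stronger inhibition
- compound 1 `O=S(=O)(Nc1ncccn1)c1ccc(Nc2nncc3ccccc23)cc1` gives 72 nM
- compound 2 `O=S(=O)(Nc1nccs1)c1ccc(Nc2nncc3ccccc23)cc1` gives 43 nM
- compound 3 `O=S(=O)(Nc1ccccn1)c1ccc(Nc2nncc3ccccc23)cc1` gives 83 nM

Compound 3 stands at 83 nM and cannot be separated from the other two, as a 1.2-fold higher number from compound 1 to compound 3 (0.06 log units; within the scatter) and a 1.9-fold higher number from compound 2 to compound 3 (0.29 log units; within the scatter) show. The next step leads to compound 4 `NS(=O)(=O)c1ccc(Nc2nncc3ccccc23)cc1` and is hydrogen in place of pyridin-2-yl on a sulfonamide nitrogen.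

The measured steps bear on this only indirectly. Besides the two above, a 1.7-fold lower number from compound 1 to compound 2 (0.22 log units; within the scatter) completes the set, and all three exchange one ring group for another on that nitrogen. Going by the values given here, no measured compound lacks such a group, so the size of its removal has not been observed. The flat set gives no ground for a large step. A small move to a higher number is expected in this assay, with a wide margin in either direction. The expected step is a 1.7-fold higher number from compound 3 to compound 4 (0.23 log units; within the scatter). Compound 4 is estimated at 140 nM, with an expected range of 40 nM to 500 nM.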

Compound 4, half-maximal inhibitory concentration: 14 nM
Compound 4: middle estimate off by 10-fold (1.00 log units), on the high side, and the stated range ends above it.
By their numbers in this assay, from the lowest: compound 4; then compounds 2, 1 and 3 (each within the scatter of the next).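

In this assay, going by these compounds alone, the ring groups on the sulfonamide nitrogen gave no separable steps among themselves, but hydrogen at that place separates from all three: a 5.9-fold lower number from compound 3 to compound 4 (0.77 log units; beyond the scatter) and a 5.1-fold lower number from compound 1 to compound 4 (0.71 log units; beyond the scatter) and a 3.1-fold lower number from compound 2 to compound 4 (0.49 log units; beyond the scatter). At this position, then, the change that registers is the loss of the ring group, and pyridin-2-yl, pyrimidin-2-yl and 1,3-thiazol-2-yl all point the same way, with no compound shown going against it. No measurement at hand accounts for this step.

As far as these compounds go, whether a small group on that nitrogen, such as methyl or acetyl, stays with compound 4 or falls back among the ring-bearing compounds remains open. So does whether a saturated ring such as cyclohexyl behaves like the aromatic rings.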